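The source may report more compounds than this note shows. Statements on the series, on what has been measured and on what is new or still open speak of the compounds shown alone.

Compound 1 `O=C(/C=C/c1ccc(N2CCCC2)cc1)c1ccc(O)cc1` gives 74.7% in an assay on isolated protein for inhibition of DNA topoisomerase 1 (Homo sapiens), tested at 100 uM (a higher number here means a stronger effect of the compound at the concentration tested, a lower number a weaker effect), and compound 2 `O=C(/C=C/c1ccc(N2CCCC2)cc1)c1ccc(F)cc1` gives 90.6%, the higher of the two numbers, the step being a number 15.9 percentage points higher from compound 1 to compound 2 (beyond the scatter). Compound 3 `O=C(/C=C/c1ccc(N2CCCC2)cc1)c1ccc([N+](=O)[O-])cc1` differs from compound 2 by nitro in place of fluoro on an aromatic carbon. Within the data shown here, the only step at hand, from compound 1 to compound 2, was modest and concerned a different exchange at the same aromatic carbon, so it bears on the new step only loosely. Compound 3 is therefore expected to stay close to compound 2, with a step of a number 5.6 percentage points lower from compound 2 to compound 3 (within the scatter). The estimated value for compound 3 is 85%, within 65% to 98%.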

Compound 3, a percentage reported as inhibition, at one concentration (the size of the read-out at that concentration, not a potency): 91.1%
Compound 3: middle estimate off by 6.1 percentage points, on the low side; the range from low to high includes it.
By their numbers in this assay, from the lowest: compound 1; then compounds 2 and 3 (each within the scatter of the next).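

At this aromatic carbon, para to a large group, nitro and fluoro cannot be told apart in this assay (a number 0.5 percentage points higher from compound 2 to compound 3 (within the scatter)), even though nitro brings more heavy atoms and two hydrogen-bond acceptors. Nitro in place of hydroxy also gives a clear step (a number 16.4 percentage points higher from compound 1 to compound 3 (beyond the scatter)), so compound 1 stands apart from the other two. Nothing at hand explains this pattern. Going by these compounds, whether an amine, a carboxylic acid or a methoxy group here would read with hydroxy or with fluoro and nitro remains open. A single-concentration read-out also leaves open whether compound 2 and compound 3 differ in potency.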